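From Phenoxy to Pyridinylsulfanyl: An Expected Step

The compounds below may be only part of what the source reports. "The series", "measured", "known", "first", "only" and "open" are said of these compounds alone.

Compound 1 `N#Cc1ncc2cc(COc3ccccc3)n(CCC3CCCCC3)c2n1` gives 10 nM in an assay on isolated protein for inhibition of cathepsin S (Homo sapiens), read by fluorescence; on this read-out lower numbers stand for stronger inhibition and higher numbers for weaker inhibition.
Compound 2 `CC(C)(C)CCCn1c(Cc2ccc(Cl)cc2)cc2cnc(C#N)nc21` gives 320 nM.
Compound 3 `CC(C)(C)CCn1c(Cc2ccc(Cl)cc2)cc2cnc(C#N)nc21` gives 2 nM.

Compound 1 stands second highest of the three numbers: compound 3 gives a lower number, compound 2 a higher one. Among the measured compounds shown here, the only step between neighbours, a 160-fold lower number from compound 2 to compound 3 (2.20 log units; beyond the scatter), concerns the chain on the aromatic nitrogen, a place left untouched here. Compound 4 `N#Cc1ncc2cc(CSc3ccncc3)n(CCC3CCCCC3)c2n1` differs from compound 1 by (pyridin-4-yl)sulfanyl in place of phenoxy on a saturated chain carbon bound to an aromatic carbon. For the measured compounds named here, no measured step bears on this change, so the expectation rests on compound 1 alone and is wide. Compound 4 is expected to show a 1.5-fold higher number from compound 1 to compound 4 (0.18 log units; within the scatter), a step not beyond the scatter. The estimate for compound 4 is 15 nM, with a range from 4 nM to 60 nM.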

Compound 4, half-maximal inhibitory concentration: 6 nM
Beside the measured number, compound 4's estimate is 2.5-fold (0.40 log units) above it, within the range that was stated.
By their numbers in this assay, from the lowest: compound 3; then compounds 4 and 1 (each within the scatter of the next); then compound 2.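

With a 1.7-fold lower number from compound 1 to compound 4 (0.22 log units; within the scatter), (pyridin-4-yl)sulfanyl in place of phenoxy on a saturated chain carbon bound to an aromatic carbon leaves the number in this assay within the scatter. This is the first step shown at this position, and it indicates that the position tolerates this change of both linking atom and ring. No measurement shown gives a reason for this result.

On these data alone, the change alters the linking atom and the ring together, so the separate contributions of each remain open. Phenylsulfanyl and (pyridin-4-yl)oxy would separate them, while an amine at this place also remains untested among the compounds shown.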